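Adding a Second Amidoxime Arm to Compound 2

A few compounds are considered here, and "the series" means these few. Any claim that something is new, unique, unknown or untested is made for them only; others in the source may bear on it.

Measured compounds:
- compound 1, `N/C(=N\O)c1ccc(C(=O)CS(=O)(=O)c2ccccc2)cc1`, > 125000 nM
- compound 2, `N/C(=N\O)c1ccc(C2=C(S(=O)(=O)c3ccccc3)CC(c3ccccc3)(c3ccccc3)O2)cc1`, 30600 nM
- compound 3, `N/C(=N\O)c1ccc(S(=O)(=O)C2=C(c3ccccc3)OC(c3ccccc3)(c3ccccc3)C2)cc1`, 37900 nM

Three compounds were tested in an ADME assay on THP-1 cells (Homo sapiens) for cytotoxicity, read by flow cytometry, with a stated time of 72 h; a lower number here means a stronger inhibitor, a higher number a weaker inhibitor. Compound 1 reached only a limit, (the limit of > 125000 nM in this assay, at which 1 of the 3 values shown sits), so no number stands for it. Compound 2 gives 30600 nM in this assay. Compound 3 gives 37900 nM, and the two numbers sit within the scatter of each other, so nothing separates compound 2 from compound 3 on these data.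

Compound 4, `N/C(=N\O)c1ccc(Nc2ccc(S(=O)(=O)C3=C(c4ccc(/C(N)=N/O)cc4)OC(c4ccccc4)(c4ccccc4)C3)cc2)cc1`, has not yet been measured in this assay. It differs from compound 2 in one place: a group of 11 heavy atoms (7 carbon, 3 nitrogen, 1 oxygen; one six-membered aromatic ring of carbon only) in place of a hydrogen atom, on an aromatic carbon. Within the data shown here, no measured pair shows a change of this kind, so no size of step can be read from the data; the expectation is a step near the scatter, if anything toward a lower number. Compound 4 is therefore estimated at 22000 nM in this assay, between 7000 nM and 70000 nM, which is the expected step of a 1.4-fold lower number from compound 2 to compound 4 (0.14 log units; within the scatter).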

Compound 4, half-maximal inhibitory concentration: > 50000 nM
Compound 4: no number, only a limit; the forecaster's own chance of this, stated with the estimate: 10%; at least 2.2-fold (0.35 log units) between middle value and limit.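

Among these compounds, this is the first measured change at this aromatic carbon, para to a large group: no earlier pair among compound 1, compound 2 and compound 3 carried a change of this kind. Placing the group of 11 heavy atoms there in place of a hydrogen atom gives an at least 1.6-fold higher number from compound 2 to compound 4 (0.21 log units; that floor lies within the scatter), so the change brings no lower number in this assay, although the floor of the step does not by itself establish a rise beyond the scatter. Compound 4 stands at a limit, not at a number: the limit of > 50000 nM in this assay, at which 1 of the 4 values shown sits.

How far the true value of compound 4 lies from that of compound 2 cannot be read from these data. From the compounds shown here alone, it also remains open whether a smaller group on the same carbon, such as an amine or a carboxylic acid, would give a measurable number.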